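A few compounds are considered here, and "the series" means these few. Any claim that something is new, unique, unknown or untested is made for them only; others in the source may bear on it.

In an assay on CHO cells for displacement of a labelled ligand from prostaglandin E2 receptor EP3 subtype (Homo sapiens), read by radioligand binding (on this read-out higher numbers stand for weaker inhibition and lower numbers for stronger inhibition), three compounds built on one shared core have been measured. Compound 1 `CC(C)C(c1ncc[nH]1)c1ccc(-c2ccc3cccc(F)c3c2)[nH]c1=O` gives 7.3 nM. Compound 2 `CC(C)C(Cc1nnn[nH]1)c1ccc(-c2ccc3cccc(F)c3c2)[nH]c1=O` gives 34 nM, and compound 3 `CC(C)C(c1ncco1)c1ccc(-c2ccc3cccc(F)c3c2)[nH]c1=O` gives 24 nM. Compound 3 thus stands second highest of the three numbers: the step of a 1.4-fold lower number from compound 2 to compound 3 (0.15 log units; within the scatter) lies within the scatter, whereas a 3.3-fold higher number from compound 1 to compound 3 (0.52 log units; beyond the scatter) lies beyond it, as does a 4.7-fold higher number from compound 1 to compound 2 (0.67 log units; beyond the scatter). Compound 4 `Cc1c[nH]c(C(c2ccc(-c3ccc4cccc(F)c4c3)[nH]c2=O)C(C)C)n1` differs from compound 3 in one place: 4-methyl-1H-imidazol-2-yl in place of 1,3-oxazol-2-yl on a saturated chain carbon bound to an aromatic carbon and a saturated chain carbon. The step of a 3.3-fold higher number from compound 1 to compound 3 (0.52 log units; beyond the scatter) bears directly on this change, as it exchanged 1H-imidazol-2-yl for the 1,3-oxazol-2-yl that now leaves; compound 4 brings an imidazole back, now carrying a methyl, and nothing measured shows what that methyl alone does. One therefore expects a downward step in this assay, roughly reversing that exchange, namely a 2.7-fold lower number from compound 3 to compound 4 (0.43 log units; beyond the scatter). Compound 4 is estimated at 9 nM, within a range from 3 nM to 27 nM.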

Compound 4, inhibition constant: 12 nM
Estimate against measurement, compound 4: 1.3-fold (0.12 log units) below, and the stated range covers the measured number.
By their numbers in this assay, from the lowest: compounds 1, 4, 3 and 2 (each within the scatter of the next, the first and the last beyond it).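

In this assay, the methyl on the imidazole ring gives a 1.6-fold higher number from compound 1 to compound 4 (0.22 log units; within the scatter), so at this place the added methyl leaves compound 4 within the scatter of compound 1. The exchange of the ring gives a 2.0-fold lower number from compound 3 to compound 4 (0.30 log units; within the scatter), which also lies within the scatter, so 4-methyl-1H-imidazol-2-yl cannot be told apart from 1,3-oxazol-2-yl here, even though the unmethylated 1H-imidazol-2-yl of compound 1 could be. Only a 2.8-fold lower number from compound 2 to compound 4 (0.45 log units; beyond the scatter) lies beyond the scatter, and it separates 4-methyl-1H-imidazol-2-yl from (1H-tetrazol-5-yl)methyl on this saturated chain carbon.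

The compounds shown leave open how an ethyl or a trifluoromethyl in place of this methyl, or a carboxylic acid in place of the ring, would read in this assay. Nothing available bears on why these steps have the sizes they do.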